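A few compounds are considered here, and "the series" means these few. Any claim that something is new, unique, unknown or untested is made for them only; others in the source may bear on it.

Measured so far:
Compound 1, `COc1cc(OC)c2cc(-c3ccc(OCc4ccccc4)cc3)c(O)nc2c1`, 10000 nM
Compound 2, `COc1ccc(-c2cc3c(OC)cc(OC)cc3n(CC(=O)OCc3ccccc3)c2=O)cc1`, 10000 nM
Compound 3, `COc1ccc(-c2cc3c(OC)cc(OC)cc3n(CC(=O)O)c2=O)cc1`, 10000 nM

In a functional assay on PC-3 cells (Homo sapiens) for cytotoxicity, read by colorimetric assay and MTT assay (a lower number here means a stronger inhibitor, a higher number a weaker inhibitor), compound 1 gives 10000 nM. In this assay compound 2 gives 10000 nM, and compound 3 gives 10000 nM. The three values stand level with one another, so none of them can be set apart from the others.

Compound 2 and compound 3 share one core and differ in a single spot: hydrogen in place of benzyl on an oxygen next to a carbonyl group. This change gave no change at the digits printed from compound 2 to compound 3 (within the scatter). Compound 1 is built on a different core; the difference between the two cores is not broken down here.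

Compound 4, `COc1cc(OC)c2cc(-c3ccc(O)cc3)c(O)nc2c1`, has not yet been measured. It stands to compound 1 as compound 3 stands to compound 2: hydrogen in place of benzyl on an oxygen on an aromatic ring. The place is not the same, though. In the pair already measured the oxygen sits next to a carbonyl group and its other neighbour is a carbonyl carbon; in compound 4 the oxygen sits on an aromatic ring and its other neighbour is an aromatic carbon. It is therefore the same kind of change, not the same change.

The expectation for compound 4 rests on compound 2 and compound 3 alone, where the removal of benzyl gave no change at the digits printed from compound 2 to compound 3 (within the scatter). The step from compound 1 is expected to be no change at the digits printed from compound 1 to compound 4 (within the scatter). The estimated value for compound 4 in this assay is 10000 nM, expected to fall between 4000 nM and 25000 nM.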

Compound 4, half-maximal inhibitory concentration: 10000 nM
Estimate against measurement, compound 4: no gap at the digits printed; the range from low to high includes it.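

Replacing benzyl with hydrogen on an oxygen on an aromatic ring gives no change at the digits printed from compound 1 to compound 4 (within the scatter) in this assay. Set beside the same kind of change on the other core, the result reads alike: the same change on two cores in this assay, no change at the digits printed (within the scatter) from compound 2 to compound 3 and no change at the digits printed (within the scatter) from compound 1 to compound 4, 1.0-fold (0.00 log units) apart, within the scatter of two such steps. This shows that, for these two pairs, removing benzyl leaves the value where it was on both cores, but it does not show that the change carries over in any wider sense: all four compounds stand level, so neither step has a size to compare, and the oxygen sits in a different place in each pair, next to a carbonyl group in one and on an aromatic ring in the other.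

The compounds shown leave open whether any other group on this oxygen, such as a longer chain ending in an amine, would set a compound apart from the level shared by compound 1 and compound 4. They also leave open whether a fluorine on the aromatic ring carrying this oxygen would give a step with a readable size, against which the removal of benzyl could be tested again.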